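Working notes: from compound 3 to compound 4

The source may hold more compounds than are shown below. What is called first, only, known or untested is meant among the compounds shown, and "the series" means these compounds.

Of the compounds shown here, three have numbers so far in a functional assay on HeLa cells (Homo sapiens) for inhibition; on this read-out higher numbers stand for weaker inhibition and lower numbers for stronger inhibition. Compound 1 `Nc1ccn(/C=C/C=O)c(=O)n1` gives 15 uM, compound 2 `Nc1nc(O)c2ncn(/C=C/C=O)c2n1` gives 24 uM, and compound 3 `Cc1cn(C)c(=O)n(/C=C/C=O)c1=O` gives 3 uM. Compound 3 thus holds the lowest number of the three, beyond the scatter from both others. Compound 4 `Cc1cn(COCCO)c(=O)n(/C=C/C=O)c1=O` differs from compound 3 by 2-hydroxyethoxy in place of hydrogen on a saturated chain carbon bound to an aromatic nitrogen, which reads, one bond further out, as methyl to (2-hydroxyethoxy)methyl. For the measured compounds named here, no measured pair covers this change, so the expectation is loose. With compound 3 at 3 uM, a rise in this assay seems likelier than a further fall. The expected move, toward weaker inhibition, is moderate: a 3.0-fold higher number from compound 3 to compound 4 (0.48 log units; beyond the scatter). Compound 4 is estimated at 9 uM, with an expected range of 3 uM to 30 uM.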

Compound 4, concentration for 50% inhibition: 6 uM
Estimate against measurement, compound 4: 1.5-fold (0.18 log units) above, within the range that was stated.
By their numbers in this assay, from the lowest: compounds 3 and 4 (each within the scatter of the next); then compounds 1 and 2 (each within the scatter of the next).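

Replacing methyl with (2-hydroxyethoxy)methyl, on a saturated chain carbon bound to an aromatic nitrogen, gives in this assay no shift that stands clear of the scatter (a 2.0-fold higher number from compound 3 to compound 4 (0.30 log units; within the scatter)). This position therefore takes 2-hydroxyethoxy, with its 4 heavy atoms, without a resolved loss on this read-out. No accompanying measurement bears on this result.

On these data alone, whether an amine, a carboxylic acid or a longer alkyl chain at this carbon would leave the read-out equally unmoved stays open. So does whether the same change would behave alike on the cores of compound 1 and compound 2.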